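Benzylsulfanyl series: trifluoromethyl on the benzyl ring

This account rests on a few compounds, and the source may have more. Where it says the series, first, only, none or still open, it means among the compounds named here.

Measured so far:
compound 1 `Cc1cc(S(=O)(=O)/N=C(\N)n2nccc2-c2ccccc2)c(SCc2ccccc2)cc1Cl` 12000 nM
compound 2 `Cc1cccc(CSc2cc(Cl)c(C)cc2S(=O)(=O)/N=C(\N)n2nc(C)cc2-c2ccccc2)c1` 34000 nM

In a functional assay on HCT-116 cells (Homo sapiens) for cytotoxicity, read by MTT assay, with a stated time of 72 h (a higher number here means a weaker inhibitor, a lower number a stronger inhibitor), compound 1 gives the lower of the two numbers; compound 2 gives 34000 nM in this assay, a gap that lies beyond the scatter. Among the measured compounds shown here, no pair differing in one place has been measured, so no step size is known.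

Compound 3 `Cc1cc(S(=O)(=O)/N=C(\N)n2nccc2-c2ccccc2)c(SCc2ccccc2C(F)(F)F)cc1Cl` is compound 1 with trifluoromethyl in place of hydrogen on an aromatic carbon. With nothing comparable measured, no step beyond the scatter is expected in either direction. The estimate for compound 3 in this assay is 10000 nM, within 3000 nM to 40000 nM, which means an expected step of a 1.2-fold lower number from compound 1 to compound 3 (0.08 log units; within the scatter).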

Compound 3, half-maximal inhibitory concentration: 16000 nM
Beside the measured number, compound 3's estimate is 1.6-fold (0.20 log units) below it; low and high end bracket the measured number.
By their numbers in this assay, from the lowest: compounds 1 and 3 (each within the scatter of the next); then compound 2.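

In this assay, this first pair differing in one place gives a 1.3-fold higher number from compound 1 to compound 3 (0.12 log units; within the scatter). On this aromatic carbon, ortho to a large group, trifluoromethyl in place of hydrogen therefore produces no step beyond the scatter, and benzyl and 2-(trifluoromethyl)benzyl cannot be told apart in this read-out. No measurement bearing on this result is available to explain it. Still open, from the compounds shown here alone, is whether an amine or a carboxylic acid on the same aromatic carbon would give a step beyond the scatter.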